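Swapping bromo for methyl on a growth inhibitor

This account rests on a few compounds, and the source may have more. Where it says the series, first, only, none or still open, it means among the compounds named here.

compound 1 `COc1ccc(C2=C(c3ccc(SC)cc3)CC3CCCN3C2=O)cc1O`: 5000 nM
compound 2 `COc1ccc(C2=C(c3ccc(SC)cc3)CC3CCCN3C2=O)cc1C`: 90 nM
compound 3 `CSc1ccc(C2=C(c3ccc(Br)cc3)C(=O)N3CCCC3C2)cc1`: 7000 nM

In a functional assay on U-251 cells (Homo sapiens) for cytotoxicity (a lower number here means a stronger inhibitor of growth, a higher number a weaker inhibitor of growth), compound 3 gives 7000 nM. Two steps place it: a 1.4-fold higher number from compound 1 to compound 3 (0.15 log units; within the scatter), but a 78-fold higher number from compound 2 to compound 3 (1.89 log units; beyond the scatter). Compound 4 `CSc1ccc(C2=C(c3ccc(C)cc3)C(=O)N3CCCC3C2)cc1` keeps the shared core and changes one group: methyl in place of bromo on an aromatic carbon, para to a large group. Among the measured compounds shown here, no measured step makes this exact swap. The closest is a 56-fold lower number from compound 1 to compound 2 (1.74 log units; beyond the scatter), where methyl replaces hydroxy, not bromo. For the measured compounds named here, that large step shows only that one small group can matter here, so a modest move toward a lower number is expected, with wide uncertainty. The expected result is a 2.8-fold lower number from compound 3 to compound 4 (0.45 log units; beyond the scatter). For compound 4 the estimated value is 2500 nM, within an expected range of 400 nM to 10000 nM.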

Compound 4, concentration for 50% growth inhibition: 400 nM
Estimate against measurement, compound 4: 6.3-fold (0.80 log units) above; the measured number falls inside the stated range.
By their numbers in this assay, from the lowest: compound 2; then compound 4; then compounds 1 and 3 (each within the scatter of the next).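

In this assay there is an 18-fold lower number from compound 3 to compound 4 (1.24 log units; beyond the scatter) when only 4-bromophenyl becomes 4-methylphenyl, so a single heavy atom para to a large group can change growth inhibition strongly. The same 4-methylphenyl compound shows a 13-fold lower number from compound 1 to compound 4 (1.10 log units; beyond the scatter) but also a 4.4-fold higher number from compound 2 to compound 4 (0.65 log units; beyond the scatter) and so compound 2 keeps the lowest number of the four. Nothing available explains why this swap matters so much.
Going by these compounds, whether a nitrile or an amine at this spot would give a lower number than methyl stays open. So does whether the gain from bromo to methyl holds in other cell lines.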